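This account rests on a few compounds, and the source may have more. Where it says the series, first, only, none or still open, it means among the compounds named here.

Compound 1 `c1ccc(-c2ccsc2)c(OCC2=NCCN2)c1`; in a functional assay for activation of Alpha-1B adrenergic receptor (Homo sapiens), read by calcium flux (on this read-out lower numbers stand for an effect already at smaller amounts and higher numbers for an effect only at larger amounts of compound), compound 1 gives 15.9 nM.
Compound 2 `Cc1ccoc1-c1ccccc1OCC1=NCCN1`; in this assay compound 2 gives < 100000 nM, which is a limit of the assay and not a number.

Compound 2 therefore stands only at a limit, the one noted as the limit of < 100000 nM in this assay, at which 1 of the 2 values shown sits, and no number is known for it. Among the compounds with values here, the one measured step, a step that the limit leaves unreadable from compound 1 to compound 2, is for that reason unreadable in size, although it runs from a clear number to a limit.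

Compound 3 `Cc1csc(-c2ccccc2OCC2=NCCN2)n1` differs from compound 2 by 4-methyl-1,3-thiazol-2-yl in place of 3-methylfuran-2-yl on an aromatic carbon. Within the data shown here, no measured step bears directly on this change. Among the measured compounds shown here, the only related pair, compound 1 and compound 2, shows that a five-membered ring with sulfur gives a clear number while the 3-methylfuran-2-yl ring gives only a limit. On that basis the step that the limit leaves unreadable from compound 2 to compound 3 is expected to move in the direction of smaller amounts, but the size is uncertain. Compound 3 is thus estimated at 2000 nM in this assay, within a range from 100 nM to 50000 nM.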

Compound 3, half-maximal effective concentration: < 100000 nM
Compound 3 ended at the assay's limit; the forecaster's own chance of this, stated with the estimate: 25%; the middle value does not contradict the limit.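

Compound 3, like compound 2, stands only at a limit in this assay, so no new step can be read from compound 3 to either compound 1 or compound 2: the limit of < 100000 nM in this assay, at which 2 of the 3 values shown sit.

The compounds shown leave open how far compound 2 and compound 3 lie from compound 1, and whether those two differ from each other at all.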